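A few compounds are considered here, and "the series" means these few. Any claim that something is new, unique, unknown or untested is made for them only; others in the source may bear on it.

Of the compounds shown here, three sharing one core have been measured in a functional assay on U-251 cells (Homo sapiens) for cytotoxicity; a lower number here means a stronger inhibitor of growth, a higher number a weaker inhibitor of growth. Compound 1 `COc1ccc(C2=C(c3ccc(SC)cc3)CC3CCCN3C2=O)cc1OC(=O)CNC(=O)OC(C)(C)C` gives 6000 nM, and compound 2 `COc1ccc(C2=C(c3ccc(SC)cc3)CC3CCCN3C2=O)cc1OC` gives 300 nM. Compound 3 `COc1ccc(C2=C(c3ccc(SC)cc3)CC3CCCN3C2=O)cc1`, at 2000 nM, holds the middle of the three numbers, lower than compound 1 and higher than compound 2. Compound 4 `CSc1ccc(C2=C(c3ccc(SC)cc3)C(=O)N3CCCC3C2)cc1` differs from compound 3 by methylsulfanyl in place of methoxy on an aromatic carbon, para to a large group: methylsulfanyl in place of methoxy on an aromatic carbon.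

Going by the values given here, no measured step makes this same exchange. The closest is a 6.7-fold higher number from compound 2 to compound 3 (0.82 log units; beyond the scatter), a modest change in which hydrogen replaces methoxy on an aromatic carbon. The other two steps, a 20-fold lower number from compound 1 to compound 2 (1.30 log units; beyond the scatter), which is large, and a 3.0-fold lower number from compound 1 to compound 3 (0.48 log units; beyond the scatter), which is modest, both remove the much bigger group of compound 1. These steps show that changes on this ring can move the number in this assay. However, each of them takes a group away, whereas here one group is exchanged for another of like count, so a smaller move is expected. No shift beyond the scatter is therefore anticipated, and the estimated step is a 1.3-fold lower number from compound 3 to compound 4 (0.12 log units; within the scatter). Compound 4 is expected at 1500 nM, with an estimated range from 500 nM to 5000 nM.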

Compound 4, concentration for 50% growth inhibition: 5000 nM
Compound 4: middle estimate off by 3.3-fold (0.52 log units), on the low side, and the stated range covers the measured number.
By their numbers in this assay, from the lowest: compound 2; then compound 3; then compounds 4 and 1 (each within the scatter of the next).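

In this assay, the exchange of methylsulfanyl for methoxy on an aromatic carbon, para to a large group, gives a 2.5-fold higher number from compound 3 to compound 4 (0.40 log units; beyond the scatter) and so lies beyond the scatter, even though the two groups match in heavy-atom count, hydrogen-bond donors and acceptors, and net charge. Each earlier step took a group away from the ring, so they could not show whether this place distinguishes between two groups of like count; this pair shows that it does, with sulfur in place of oxygen being the only difference in the atoms counted. Nothing measured here accounts for the shift, and the data give no cause for it.

The compounds shown leave open how the number would respond at this same place to other replacements for methoxy, such as an ethoxy group, a chlorine atom or an amine, and so whether methoxy or methylsulfanyl stands out among them. They also leave open whether the same exchange would move the number similarly on the core of compound 2, which carries a second methoxy group.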